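A Smaller Ester Chain on the Shared Core

This account rests on a few compounds, and the source may have more. Where it says the series, first, only, none or still open, it means among the compounds named here.

Three compounds have been tested in a functional assay on the whole organism (strain albino) for inhibition, with Rattus norvegicus as the target, read by paw edema, with a stated time of 1 h, at a dose of 20 mmol/kg by the intraperitoneal route; a higher number here means more inhibition at the dose given (going by the name of the read-out), a lower number less inhibition:

Compound 1 `N#CC1=C(NCC(=O)N2CCCC2)N(c2ccccc2)C(=O)N2CCCCC(N3CCCC3)C12` — 40.1%
Compound 2 `CCOC(=O)C(=O)NC1=C(C#N)C2C(N3CCCC3)CCCCN2C(=O)N1c1ccccc1` — 71.2%
Compound 3 `COc1ccc(/C=N/C2=C(C#N)C3C(N4CCCC4)CCCCN3C(=O)N2c2ccccc2)cc1` — 59.1%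

Compound 1 stands lowest of the three; compound 3 is nearest to it and compound 2 furthest, both beyond the scatter. Compound 4 `COC(=O)C(=O)NC1=C(C#N)C2C(N3CCCC3)CCCCN2C(=O)N1c1ccccc1` differs from compound 1 by (methoxycarbonyl)carbonyl in place of ((pyrrolidin-1-yl)carbonyl)methyl on an amine nitrogen. The step that bears on this is a number 31.1 percentage points higher from compound 1 to compound 2 (beyond the scatter), where the entering ester chain differs from that of compound 4 only by being one carbon longer. Among the measured compounds shown here, no step between compound 2 and compound 4 has been measured, so the expectation rests on that single large step. A rise of similar size is therefore expected, a number 27.9 percentage points higher from compound 1 to compound 4 (beyond the scatter). Compound 4 is estimated at 68% in this assay, with a range from 50% to 84%.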

Compound 4, a percentage reported as inhibition, in the whole organism at one dose (the size of the read-out at that dose, not a potency): 69.2%
Estimate against measurement, compound 4: 1.2 percentage points below; measured number inside the range.
By their numbers in this assay, from the lowest: compound 1; then compound 3; then compounds 4 and 2 (each within the scatter of the next).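

With (methoxycarbonyl)carbonyl on the amine nitrogen, this assay again shows a large rise over the ((pyrrolidin-1-yl)carbonyl)methyl group of compound 1 (a number 29.1 percentage points higher from compound 1 to compound 4 (beyond the scatter)), and the methyl and ethyl esters lie within the scatter of each other (a number 2 percentage points lower from compound 2 to compound 4 (within the scatter)). The methyl ester also stands clear of the group carried by compound 3 (a number 10.1 percentage points higher from compound 3 to compound 4 (beyond the scatter)). Nothing available explains these differences.

On these data alone, whether a longer ester chain, a carboxylic acid or a simple amide at this place would sit at the same level remains open.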